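The source may hold more compounds than are shown below. What is called first, only, known or untested is meant among the compounds shown, and "the series" means these compounds.

Of the compounds shown here, three have been measured in a functional assay on A549 cells (Homo sapiens) for cytotoxicity, read by MTT assay, with a stated time of 72 h (a lower number here means a stronger inhibitor, a higher number a weaker inhibitor), so far.

- compound 1 `[O-][S+](CCCCN=C=S)Cc1ccccc1` gives 7410 nM
- compound 2 `[O-][S+](CCCN=C=S)Cc1ccccc1` gives 11800 nM
- compound 3 `[O-][S+](CCCCCN=C=S)Cc1ccccc1` gives 6210 nM

Compound 3, at 6210 nM on these numbers, stands within the scatter of both other compounds, so no order can be drawn among it and them. The next compound is compound 4 `[O-][S+](CCCCCCN=C=S)Cc1ccccc1` and it differs from compound 3 by a group of 4 heavy atoms (2 carbon, 1 nitrogen, 1 sulfur; no ring) in place of a group of 3 heavy atoms (1 carbon, 1 nitrogen, 1 sulfur; no ring), on a saturated chain carbon, five bonds along the chain from a sulfur at this place. That place is on a saturated chain carbon, five bonds along the chain from a sulfur. The closest guide is a 1.2-fold lower number from compound 1 to compound 3 (0.08 log units; within the scatter) as this exchange has the same form, four bonds along the chain from a sulfur. The other two measured steps are a 1.6-fold higher number from compound 1 to compound 2 (0.20 log units; within the scatter) and a 1.9-fold lower number from compound 2 to compound 3 (0.28 log units; within the scatter) and neither leaves the scatter. On that basis, no step beyond the scatter is expected in this assay for this change. The expected step is a 1.1-fold lower number from compound 3 to compound 4 (0.04 log units; within the scatter) as an estimate and its direction is not secure. For compound 4 the estimated value is 5600 nM with an expected range from 3000 nM to 10500 nM in this assay.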

Compound 4, half-maximal inhibitory concentration: 14700 nM
Estimate against measurement, compound 4: 2.6-fold (0.42 log units) below; the measured number lies above the stated range.
By their numbers in this assay, from the lowest: compounds 3, 1, 2 and 4 (each within the scatter of the next, the first and the last beyond it).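

In this assay, for the compounds shown here, the change at this place, on a saturated chain carbon, five bonds along the chain from a sulfur, gives the only step to compound 4 that clears the scatter, a 2.4-fold higher number from compound 3 to compound 4 (0.37 log units; beyond the scatter), while a 1.2-fold higher number from compound 2 to compound 4 (0.10 log units; within the scatter) and a 2.0-fold higher number from compound 1 to compound 4 (0.30 log units; within the scatter) both stay within it. The response to chain length therefore does not run in one steady direction, and the same exchange does not give the same step at different places along the chain: the same change on two cores in this assay, a 1.6-fold higher number (0.20 log units; within the scatter) from compound 1 to compound 2 and a 2.4-fold lower number (0.37 log units; beyond the scatter) from compound 4 to compound 3, 3.8-fold (0.58 log units) apart, beyond the scatter of two such steps. A second pair of matching exchanges shows the same disagreement: the same change on two cores in this assay, a 1.9-fold lower number (0.28 log units; within the scatter) from compound 2 to compound 3 and a 2.0-fold higher number (0.30 log units; within the scatter) from compound 1 to compound 4, 3.8-fold (0.58 log units) apart, beyond the scatter of two such steps.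

Only compound 3 and compound 4 are separated beyond the scatter, so the compounds shown fix no best chain length. On these data alone, whether a longer chain would continue this rise, or an amine on the chain would change it, remains open.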